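A few compounds are considered here, and "the series" means these few. Any claim that something is new, unique, unknown or untested is made for them only; others in the source may bear on it.

Measured so far:
compound 1, `CCC[C@@H](N)C(=O)NCc1ccccc1`, 21 mg/kg
compound 2, `N[C@@H](C(=O)NCc1ccccc1)C1CCCCC1`, 28 mg/kg

Both compounds share one core and differ only in the side group on the saturated chain carbon bound to an amine nitrogen and a carbonyl carbon. In a functional assay on the whole organism (strain NMRI) with Mus musculus as the target, in the maximal electroshock model, with a stated time of 30 min (on this read-out higher numbers stand for an effect only at larger amounts of compound and lower numbers for an effect already at smaller amounts), compound 1 gives 21 mg/kg and compound 2 gives 28 mg/kg. Among the measured compounds shown here, the one change seen so far is cyclohexyl in place of propyl, and it gave a 1.3-fold higher number from compound 1 to compound 2 (0.12 log units; within the scatter), so compound 2 cannot be told apart from compound 1 on this read-out.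

Compound 3 `CC(C)(C)[C@@H](N)C(=O)NCc1ccccc1` is not yet measured. It differs from compound 2 by tert-butyl in place of cyclohexyl on a saturated chain carbon bound to an amine nitrogen and a carbonyl carbon. For the measured compounds named here, the only step that bears on this is a 1.3-fold higher number from compound 1 to compound 2 (0.12 log units; within the scatter), which stayed within the scatter, and nothing here separates one side group from another. Compound 3 is therefore expected to show a 1.1-fold higher number from compound 2 to compound 3 (0.03 log units; within the scatter), no step beyond the scatter. For compound 3 the estimate in this assay is 30 mg/kg, in a range of 12 mg/kg to 75 mg/kg.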

Compound 3, dose for half-maximal effect: 13 mg/kg
Estimate against measurement, compound 3: 2.3-fold (0.36 log units) above; measured number inside the range.
By their numbers in this assay, from the lowest: compounds 3, 1 and 2 (each within the scatter of the next, the first and the last beyond it).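

In this assay the side group on the saturated chain carbon bound to an amine nitrogen and a carbonyl carbon now gives its first step beyond the scatter, modest in size: a 2.2-fold lower number from compound 2 to compound 3 (0.33 log units; beyond the scatter) when tert-butyl replaces cyclohexyl. The other new step, a 1.6-fold lower number from compound 1 to compound 3 (0.21 log units; within the scatter) with tert-butyl in place of propyl, stays within the scatter, so the separation holds only between tert-butyl and cyclohexyl, and these three compounds give no ranking that runs through all of them. Nothing available explains why tert-butyl and cyclohexyl differ here.

The compounds shown leave open how a side group carrying a hydroxyl or an amine, or a flat phenyl ring, would read at this position. They also leave open whether the difference between tert-butyl and cyclohexyl would hold if another part of the shared core were changed.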